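The source may report more compounds than this note shows. Statements on the series, on what has been measured and on what is new or still open speak of the compounds shown alone.

Measured in a functional assay on HEK293 cells for agonist activity at G-protein coupled receptor 39 (Homo sapiens), read by scintillation proximity assay and inositol phosphate accumulation, with a stated time of 75 min; a higher number here means that more compound is needed for the effect, a lower number that less compound is needed:
compound 1 `Cc1nn(-c2ncnc3nc[nH]c23)c2c1C(OC1CCCC1)CC(=O)N2`, 62 nM
compound 2 `Cc1nn(-c2ncnc3nc[nH]c23)c2c1C(OCc1cc(F)cc3c1OCOC3)CC(=O)N2`, 30 nM
compound 3 `Cc1nn(-c2ncnc3nc[nH]c23)c2c1C(c1ccc(F)cc1Cl)CC(=O)N2`, 280 nM

Compound 3 gives the highest number of the three; the step of a 4.5-fold higher number from compound 1 to compound 3 (0.65 log units; beyond the scatter) separates it from compound 1, and its gap to compound 2 is wider still, beyond the scatter. Compound 4 `Cc1cc(C)n(CCOC2CC(=O)Nc3c2c(C)nn3-c2ncnc3nc[nH]c23)n1` is to be measured in this assay. The change from compound 3 is a group of 10 heavy atoms (7 carbon, 2 nitrogen, 1 oxygen; one five-membered aromatic ring with 2 hetero atoms) in place of a group of 8 heavy atoms (6 carbon, 1 fluorine, 1 chlorine; one six-membered aromatic ring of carbon only), on a saturated ring carbon. Among the measured compounds shown here, the only measured step that bears on it is a 4.5-fold higher number from compound 1 to compound 3 (0.65 log units; beyond the scatter), in which an oxygen-linked saturated ring gave way to the aromatic ring and the number rose. Compound 4 returns to an oxygen-linked group, as in compound 1 and compound 2, so a step back down, beyond the scatter, is expected: a 5.6-fold lower number from compound 3 to compound 4 (0.75 log units; beyond the scatter). Compound 4 is therefore estimated at 50 nM, range 18 nM to 150 nM.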

Compound 4, half-maximal effective concentration: 2000 nM
For compound 4 the middle estimate is 40-fold (1.60 log units) below the measured one; measured number outside the range, above it.
By their numbers in this assay, from the lowest: compound 2; then compound 1; then compound 3; then compound 4.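

In this assay an oxygen on the saturated ring carbon does not by itself keep the number low: 2-(3,5-dimethyl-1H-pyrazol-1-yl)ethyl in place of cyclopentyl brings a 32-fold higher number from compound 1 to compound 4 (1.51 log units; beyond the scatter) and, against the group of compound 2 on that oxygen, brings a 67-fold higher number from compound 2 to compound 4 (1.82 log units; beyond the scatter) as well. This oxygen-linked chain also ranks behind 2-chloro-4-fluorophenyl on the saturated ring carbon, with a 7.1-fold higher number from compound 3 to compound 4 (0.85 log units; beyond the scatter) in the same assay series. No measurement shown accounts for this loss.

As far as these compounds go, whether the loss follows the pyrazole ring, its dimethyl substitution or the ethyl chain stays open. An unsubstituted pyrazole, a phenyl ring on the same chain or a shorter chain would separate these.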